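Amino in place of phenyl: notes on the series

The compounds below may be only part of what the source reports. "The series", "measured", "known", "first", "only" and "open" are said of these compounds alone.

- Compound 1 `CCOC(=O)CNc1nc(-n2nc(-c3ccccn3)nc2N)c2cc(OC)c(OC)cc2n1`: in a physicochemical assay for solubility, in phosphate buffer, with a stated time of 18 h, at pH 7.4 (a lower number here means a less soluble compound, a higher number a more soluble compound), 48000 nM
- Compound 2 `CCN(CC)c1nc(-n2nc(-c3ccccn3)nc2N)c2cc(OC)c(OC)cc2n1`: 6000 nM
- Compound 3 `COc1cc2nc(-c3ccccc3)nc(-n3nc(-c4ccccn4)nc3N)c2cc1OC`: 2000 nM

Compound 3 gives the lowest number of the three, at 2000 nM in this assay. Its nearest neighbour is compound 2 and its furthest is compound 1.

The next change gives compound 4 `COc1cc2nc(N)nc(-n3nc(-c4ccccn4)nc3N)c2cc1OC`, with amino in place of phenyl on an aromatic carbon.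

Among the compounds with values here, two measured steps bear on this, and both bring phenyl in: a 3.0-fold lower number from compound 2 to compound 3 (0.48 log units; beyond the scatter), and a 24-fold lower number from compound 1 to compound 3 (1.38 log units; beyond the scatter). Phenyl leaves in the change to compound 4, so a higher number is expected. The size is less certain, as an 8.0-fold lower number from compound 1 to compound 2 (0.90 log units; beyond the scatter) shows that the outcome depends on the group that replaces phenyl, and plain amino has not been measured on this core.

The expected change is a 7.5-fold higher number from compound 3 to compound 4 (0.88 log units; beyond the scatter), which would lie beyond the scatter. For compound 4 the estimate is 15000 nM, with an expected range of 4000 nM to 60000 nM.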

Compound 4, solubility: 27000 nM
Compound 4: the middle estimate sits 1.8-fold (0.26 log units) below what was measured; measured number inside the range.
By their numbers in this assay, from the lowest: compound 3; then compound 2; then compounds 4 and 1 (each within the scatter of the next).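

Within the data shown here, on the aromatic carbon between two ring nitrogen atoms, amino in place of phenyl gives a 14-fold higher number from compound 3 to compound 4 (1.13 log units; beyond the scatter) in this assay and this is the first reading of the unsubstituted amino group at this position. Substitution on that nitrogen does not read the same way for the two substituted compounds: amino in place of diethylamino gives a 4.5-fold higher number from compound 2 to compound 4 (0.65 log units; beyond the scatter) and lies beyond the scatter, whereas hydrogen in place of (ethoxycarbonyl)methyl gives a 1.8-fold lower number from compound 1 to compound 4 (0.25 log units; within the scatter) and lies within it, so that pair cannot be told apart. Nothing shown gives a reason for these steps.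

Open, as far as these compounds go, is where a methylamino or morpholine group on this carbon would stand against amino and diethylamino. Also open is how a carboxylic acid in place of the ethyl ester of compound 1 would read in this assay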